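Deoxyribose-linked uracil isoxazoles: cytotoxicity notes

A few compounds are considered here, and "the series" means these few. Any claim that something is new, unique, unknown or untested is made for them only; others in the source may bear on it.

Measured compounds:
compound 1 `CC(C)(C)c1ccc(-c2cc(-c3cn([C@H]4C[C@H](O)[C@@H](CO)O4)c(=O)[nH]c3=O)on2)cc1` — 88%
compound 2 `CC(=O)OC[C@H]1O[C@@H](n2cc(-c3cc(C)no3)c(=O)[nH]c2=O)C[C@@H]1OC(C)=O` — 90.8%

In a functional assay on NUGC-3 cells (Homo sapiens) for cytotoxicity, read by sulforhodamine B assay, tested at 10 uM (on this read-out higher numbers stand for more inhibition at the one concentration tested (going by the name of the read-out) and lower numbers for less inhibition), compound 1 gives 88%, and compound 2 gives 90.8%. The two numbers lie within the usual scatter of each other, so no order can be read between compound 1 and compound 2 on this read-out; both show strong inhibition at the single concentration tested. Within the data shown here, no single-change step between these two measured compounds is available, as they differ in several places at once.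

Compound 3 `CCCCCCCCc1cc(-c2cn([C@H]3C[C@H](O)[C@@H](CO)O3)c(=O)[nH]c2=O)on1` is not yet measured. It differs from compound 1 as follows: octyl in place of 4-(tert-butyl)phenyl on an aromatic carbon. The group that leaves carries one six-membered aromatic ring of carbon only; the group that enters is a chain with no ring. Neither carries hydrogen-bond donors or acceptors.

Among the measured compounds shown here, with only two measured compounds and no step of a single change to compare against, the expected step in this assay is small, downward at most, and likely not beyond the scatter. For compound 3 the estimate is 80%, with a range of 55% to 95%. The expected step is a number 8 percentage points lower from compound 1 to compound 3 (within the scatter).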

Compound 3, a percentage reported as inhibition, at one concentration (the size of the read-out at that concentration, not a potency): 76.4%
Estimate against measurement, compound 3: 3.6 percentage points above, and the stated range covers the measured number.
By their numbers in this assay, from the lowest: compound 3; then compounds 1 and 2 (each within the scatter of the next).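

In this assay, the place on an aromatic carbon of the five-membered aromatic ring, next to the ring nitrogen, proves sensitive to the group it carries: octyl in place of 4-(tert-butyl)phenyl gives a number 11.6 percentage points lower from compound 1 to compound 3 (beyond the scatter), a modest step and the first in the series that can be read at a single place. The group that leaves carries one six-membered aromatic ring of carbon only and the group that enters is a chain with no ring, while neither carries hydrogen-bond donors or acceptors, so this pair separates ring from chain without any change in those counts, and compound 3 still gives 76.4% at the one concentration tested. Nothing measured here accounts for the step.

One pair cannot tell whether the loss of the ring or the shape and length of the chain goes with the step, and phenyl without the tert-butyl group, butyl or dodecyl at this place would separate these readings. On these data alone, whether this place accepts a group with hydrogen-bond donors or acceptors also stays open, for instance an amine or a carboxylic acid at the end of the octyl chain.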